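This account rests on a few compounds, and the source may have more. Where it says the series, first, only, none or still open, it means among the compounds named here.

Compound 1 `CC(C)c1ccc(-c2nc(SCc3cn(CC(=O)NC(=O)Nc4ccccn4)nn3)nc(Nc3ccccc3Cl)c2C#N)cc1` gives 23400 nM in a functional assay on ECa-109 cells (Homo sapiens) for inhibition, read by MTT assay, with a stated time of 72 h; on this read-out higher numbers stand for weaker inhibition and lower numbers for stronger inhibition.
Compound 2 `CC(C)c1ccc(-c2nc(SCc3cn(CC(=O)NC(=O)Nc4ccccn4)nn3)nc(Nc3ccc(F)cc3)c2C#N)cc1` gives only a limit, > 64000 nM, in this assay.

Compound 2 thus sits at the limit of > 64000 nM in this assay, at which 1 of the 2 values shown sits, with no number beneath it. Compound 3 `CC(C)c1ccc(-c2nc(SCc3cn(CC(=O)NC(=O)Nc4ccccn4)nn3)nc(Nc3ccc(Cl)cc3)c2C#N)cc1` differs from compound 2 by chloro in place of fluoro on an aromatic carbon. Among the measured compounds shown here, only one measured step is known, an at least 2.7-fold higher number from compound 1 to compound 2 (0.43 log units; beyond the scatter), and it changes both the halogen and its place at once, so it does not isolate the chloro-for-fluoro exchange. The expected step is a number no higher from compound 2 to compound 3 (the limit leaves the size open), none beyond the scatter. Compound 3 is expected at 64000 nM, between 20000 nM and 200000 nM.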

Compound 3, half-maximal inhibitory concentration: 11200 nM
The estimate for compound 3 lay 5.7-fold (0.76 log units) above the measured number; measured number below the stated range.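

In this assay, chloro in place of fluoro gives an at least 5.7-fold lower number from compound 2 to compound 3 (0.75 log units; beyond the scatter), which isolates the halogen at one unchanged place, something the earlier pair could not do. From the compounds shown here alone, compound 2 gives a limit and not a number, so the size of this step stays open: the limit of > 64000 nM in this assay, at which 1 of the 3 values shown sits. With chloro kept and only its place changed, 4-chlorophenyl in place of 2-chlorophenyl gives a 2.1-fold lower number from compound 1 to compound 3 (0.32 log units; beyond the scatter), so the place of the halogen also counts, modestly. The compounds shown leave open how bromo, methyl or methoxy would read at this place, and how an unsubstituted phenyl would compare.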